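From 4-methoxyphenyl to 4-nitrophenyl in compound 2

The source may hold more compounds than are shown below. What is called first, only, known or untested is meant among the compounds shown, and "the series" means these compounds.

Measured so far in a functional assay on B16-F10 cells (Mus musculus) for antiproliferative activity, read by MTT assay, with a stated time of 48 h (a lower number here means a stronger inhibitor, a higher number a weaker inhibitor), with these results:
- compound 1 `CC(=O)N1N=C(c2ccccc2)CC1c1ccc2c(c1)OCCO2` at 39500 nM
- compound 2 `COc1ccc(C2=NN(C(C)=O)C(c3ccc4c(c3)OCCO4)C2)cc1` at 31700 nM

Compound 2 stands at 31700 nM in this assay and lies within the scatter of compound 1 (39500 nM), so no order can be read between the two. Compound 3 (`CC(=O)N1N=C(c2ccc([N+](=O)[O-])cc2)CC1c1ccc2c(c1)OCCO2`) carries nitro in place of methoxy on an aromatic carbon para to a large group. Within the data shown here, one measured step bears on this change. It put methoxy in place of hydrogen on the same aromatic carbon (a 1.2-fold lower number from compound 1 to compound 2 (0.10 log units; within the scatter)) and gives no sign that a substituent there moves the number. Among the measured compounds shown here, no nitro compound has been measured yet, so that single step is a thin basis and the range has to stay wide. No step beyond the scatter is therefore expected in this assay, and no direction is assigned. Compound 3 is estimated at 30000 nM (expected range 10000 nM to 70000 nM). The estimated step is small (a 1.1-fold lower number from compound 2 to compound 3 (0.02 log units; within the scatter)).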

Compound 3, half-maximal inhibitory concentration: 57800 nM
For compound 3 the middle estimate is 1.9-fold (0.28 log units) below the measured one; the measured number falls inside the stated range.
By their numbers in this assay, from the lowest: compounds 2, 1 and 3 (each within the scatter of the next).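

In this assay, the change from 4-methoxyphenyl to 4-nitrophenyl gives a 1.8-fold higher number from compound 2 to compound 3 (0.26 log units; within the scatter) and replacing hydrogen with nitro on the same aromatic carbon gives a 1.5-fold higher number from compound 1 to compound 3 (0.17 log units; within the scatter), so this position now has a second substituent to compare with hydrogen. Hydrogen, methoxy and nitro, which differ in heavy atoms and hydrogen-bond acceptors, therefore give three numbers with every listed step within the scatter, and no order can be read among them at this carbon para to a large group. No measurement bears on what lies behind these numbers.

From the compounds shown here alone, it remains open whether an amine, a carboxylic acid or a longer alkoxy chain on this aromatic carbon would give a step beyond the scatter in this assay, or would simply join the three groups already compared. Also open, going by these compounds, is whether changes elsewhere in the shared core, such as replacing the acetyl group with a longer acyl chain, would move the number more than any change at this position has so far.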